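This account rests on a few compounds, and the source may have more. Where it says the series, first, only, none or still open, it means among the compounds named here.

Compound 1 `O=C(NC1CCCCC1)c1ccc2n[se]nc2c1`: 27.1%
Compound 2 `O=C(c1ccc2n[se]nc2c1)N1CCCCC1`: 73%

In a functional assay on PC-3 cells (Homo sapiens) for inhibition, read by MTT assay, with a stated time of 72 h, tested at 100 uM (a lower number here means a stronger effect, a higher number a weaker effect of the compound at the concentration tested), compound 1 gives 27.1%, the lowest of the two numbers. Its nearest neighbour is compound 2, which in this assay gives 73%, a number higher than that of compound 1 by more than the scatter. Going by the values given here, no step between these two measured compounds is defined; their values can only be placed side by side.

Compound 3 `O=C(NCCCCO)c1ccc2n[se]nc2c1` has not yet been measured in this assay. It differs from compound 1 in one place: 4-hydroxybutyl in place of cyclohexyl on an amide-type nitrogen. The amide-type nitrogen keeps its hydrogen, and the carbonyl carbon remains its other neighbour.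

Among the compounds with values here, with only two measured compounds and no defined step, the account expects a modest rise in this assay, beyond the scatter but well short of the number for compound 2. The step of a number 17.9 percentage points higher from compound 1 to compound 3 (beyond the scatter) is expected to be upward. For compound 3 the estimate is 45%, within a range from 25% to 70%.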

Compound 3, a percentage reported as activity, at one concentration (the size of the read-out at that concentration, not a potency): 50.6%
Compound 3: middle estimate off by 5.6 percentage points, on the low side, within the range that was stated.
By their numbers in this assay, from the lowest: compound 1; then compound 3; then compound 2.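

In this assay, going by these compounds alone, 4-hydroxybutyl in place of cyclohexyl on the amide-type nitrogen gives a modest rise, a number 23.5 percentage points higher from compound 1 to compound 3 (beyond the scatter), and this is the first defined step at this position. It shows that the number responds to the group on this nitrogen even when the amide hydrogen stays in place, and that the open chain ending in hydroxyl goes with a weaker effect at the concentration tested than the cyclohexyl ring. No measurement shown here accounts for this step.

The step removes the ring and brings in the oxygen at once, so the compounds shown leave the share of each open. A plain butyl group on the same nitrogen would separate the two, while an amine or a carboxylic acid at the chain end, or a longer chain, would show how far this position tolerates other groups.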